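The compounds below may be only part of what the source reports. "The series", "measured", "known", "first", "only" and "open" are said of these compounds alone.

Values in an ADME assay (liver) for metabolic stability, with Liver microsome (Homo sapiens) as the target, using microsomes, with a stated time of 40 min; on this read-out higher numbers stand for a more stable compound and lower numbers for a less stable compound:
- compound 1 `N[C@H]1CC[C@H](Nc2ccc3ncc(-c4cnc(Nc5ccccc5)nc4)n3n2)CC1`: 89%
- compound 2 `N[C@H]1CC[C@H](Nc2ccc3ncc(-c4cnc(Nc5ncccc5F)nc4)n3n2)CC1`: 93%
- compound 3 `Cc1ccc(Nc2ncc(-c3cnc4ccc(N[C@H]5CC[C@H](N)CC5)nn34)cn2)nc1`: 92%

Compound 3 stands level with the other two within the scatter. The measured steps are a number 3 percentage points higher from compound 1 to compound 3 (within the scatter) and a number 1 percentage points lower from compound 2 to compound 3 (within the scatter), and the remaining one is a number 4 percentage points higher from compound 1 to compound 2 (within the scatter). All three change the group on the same nitrogen, and none goes beyond the scatter.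

The next analogue is compound 4 `N[C@H]1CC[C@H](Nc2ccc3ncc(-c4cnc(NCc5ccccn5)nc4)n3n2)CC1`. Relative to compound 3, it carries (pyridin-2-yl)methyl in place of 5-methylpyridin-2-yl on a nitrogen on an aromatic ring. The two have the same atoms, joined differently.

The three measured steps bear on this place, but none of them brings in a (pyridin-2-yl)methyl group, so the precedent is only partial. Compound 3 at 92% lies near the top of the scale, which leaves more room downward than upward. The expected result is a small drop that stays within the scatter, estimated as a number 7 percentage points lower from compound 3 to compound 4 (within the scatter). For compound 4 the estimated value is 85%, with an expected range from 70% to 95%.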

Compound 4, percent of the compound remaining in the Liver microsome assay: 95%
For compound 4 the middle estimate is 10 percentage points below the measured one, and the stated range covers the measured number.
By their numbers in the Liver microsome assay, from the lowest: compounds 1, 3, 2 and 4 (each within the scatter of the next).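

In the Liver microsome assay, a (pyridin-2-yl)methyl group on this nitrogen stays level with all three groups seen there before: a number 3 percentage points higher from compound 3 to compound 4 (within the scatter), a number 2 percentage points higher from compound 2 to compound 4 (within the scatter) and a number 6 percentage points higher from compound 1 to compound 4 (within the scatter). The earlier steps shown here only exchanged one aromatic ring on the nitrogen for another, so this position now also accepts a ring held on a carbon link with no step beyond the scatter in this read-out. The same exchange of atoms does separate the pair in a physicochemical assay for lipophilicity (on this read-out lower numbers stand for lower lipophilicity and higher numbers for higher lipophilicity), where lipophilicity differs beyond the scatter: the measured distribution coefficient of compound 3, 1.1, and of compound 4, 0.4, a number 0.70 log units lower (beyond the scatter)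

In the physicochemical assay compound 3 gives 1.1 and compound 4 gives 0.4. The compounds shown cannot tell whether that shift goes with the methyl leaving the ring or with the new link to the nitrogen. As far as these compounds go, it also remains open whether a longer chain such as 2-(pyridin-2-yl)ethyl, or a carboxylic acid on the ring, would stay level in the Liver microsome assay.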